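Swapping Bromo for Hydroxy on the Hydrazone Aryl Ring

A few compounds are considered here, and "the series" means these few. Any claim that something is new, unique, unknown or untested is made for them only; others in the source may bear on it.

Measured so far in a functional assay on MKN-45 cells (Homo sapiens) for cytotoxicity, read by MTT assay, with a stated time of 72 h; a higher number here means a weaker inhibitor, a lower number a stronger inhibitor:
Compound 1 `CN(C)CCn1cnnc1-c1cc(Oc2ccc(NC(=O)N/N=C/c3c(Cl)cccc3Cl)cc2F)ccn1` gives 160 nM.
Compound 2 `CN(C)CCn1cnnc1-c1cc(Oc2ccc(NC(=O)N/N=C/c3ccccc3O[N+](=O)[O-])cc2F)ccn1` gives 1020 nM.
Compound 3 `CN(C)CCn1cnnc1-c1cc(Oc2ccc(NC(=O)N/N=C/c3cccc(Br)c3)cc2F)ccn1` gives 450 nM.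

All three share one core and differ only in the aryl ring on the carbon with a double bond to nitrogen. Compound 3 stands second highest of the three numbers: a 2.3-fold lower number from compound 2 to compound 3 (0.36 log units; beyond the scatter), while a 2.8-fold higher number from compound 1 to compound 3 (0.45 log units; beyond the scatter). Compound 4 `CN(C)CCn1cnnc1-c1cc(Oc2ccc(NC(=O)N/N=C/c3cccc(O)c3)cc2F)ccn1` differs from compound 3 by hydroxy in place of bromo on an aromatic carbon. Going by the values given here, no measured step exchanges a halogen for a hydroxy, so guidance is indirect; every measured change of this ring was modest, the largest being a 6.4-fold higher number from compound 1 to compound 2 (0.80 log units; beyond the scatter). A modest step, most likely to a higher number, is therefore expected. Compound 4 is estimated at 800 nM in this assay, between 250 nM and 2500 nM. That estimate means an expected 1.8-fold higher number from compound 3 to compound 4 (0.25 log units; within the scatter).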

Compound 4, half-maximal inhibitory concentration: 1370 nM
The estimate for compound 4 lay 1.7-fold (0.23 log units) below the measured number; the range from low to high includes it.
By their numbers in this assay, from the lowest: compound 1; then compound 3; then compounds 2 and 4 (each within the scatter of the next).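

In this assay, going by these compounds alone, hydroxy in place of bromo on this aromatic carbon weakens the compound beyond the scatter (a 3.0-fold higher number from compound 3 to compound 4 (0.48 log units; beyond the scatter)), the only measured exchange of a halogen for a hydroxy here. The 3-hydroxyphenyl ring is not separated from the 2-(nitrooxy)phenyl ring (a 1.3-fold higher number from compound 2 to compound 4 (0.13 log units; within the scatter)) and stays behind the 2,6-dichlorophenyl ring (an 8.6-fold higher number from compound 1 to compound 4 (0.93 log units; beyond the scatter)). Nothing available explains the loss. From the compounds shown here alone, whether a methoxy group, an amine or a carboxylic acid on this carbon would behave like bromo or like hydroxy remains open.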